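The source may hold more compounds than are shown below. What is called first, only, known or untested is meant among the compounds shown, and "the series" means these compounds.

Compound 1 `C[C@@H](Oc1cc2ccn(CCC(=O)O)c2cc1Cl)c1ccccn1`: 2.17
Compound 2 `CC(C)Cc1cc2oc(=O)n(CCC(=O)O)c2cc1Cl`: 3.03
Compound 3 `Cc1ccc([C@@H](C)Oc2cc3onc(CCC(=O)O)c3cc2Cl)nn1`: 2.97

These three acids were read in a physicochemical assay for lipophilicity, read by HPLC, at pH 7.4; a higher number here means a more lipophilic compound, a lower number a more polar compound. Compound 3 reads 2.97, which is within the scatter of compound 2, and it stands beyond the scatter above compound 1. Compound 4 `C[C@@H](Oc1cc2onc(CCC(=O)O)c2cc1Cl)c1ccc(Cl)cn1` is still to be measured. It differs from compound 3 in one place: 5-chloropyridin-2-yl in place of 6-methylpyridazin-3-yl on a saturated chain carbon bound to an oxygen on an aromatic ring and a saturated chain carbon. Here 5-chloropyridin-2-yl stands in place of 6-methylpyridazin-3-yl on a saturated chain carbon bound to an oxygen on an aromatic ring and a saturated chain carbon. Going by the values given here, no measured pair differs in one place, so the expectation rests on this structural change alone. A moderate rise in this assay, beyond the scatter, is expected. The estimated change is a number 0.63 log units higher from compound 3 to compound 4 (beyond the scatter). For compound 4 the expected value is 3.6, with an estimated range of 3.2 to 4.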

Compound 4, distribution coefficient: 2.91
Compound 4: the middle estimate sits 0.69 log units above what was measured, and the stated range ends above it.
By their numbers in this assay, from the lowest: compound 1; then compounds 4, 3 and 2 (each within the scatter of the next).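

In this assay, 5-chloropyridin-2-yl in place of 6-methylpyridazin-3-yl on this saturated chain carbon gives a number 0.06 log units lower from compound 3 to compound 4 (within the scatter). Going by these compounds alone, this is the first one-place step in the set, and it shows that this position can take either ring, with one hydrogen-bond acceptor fewer and a chlorine entering, without a reading that stands apart from the scatter. No measured evidence bears on why the two rings read alike. The compounds shown leave open whether a ring carrying an amine, or a plain phenyl ring, on this carbon would read the same.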